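The source may hold more compounds than are shown below. What is called first, only, known or untested is meant among the compounds shown, and "the series" means these compounds.

Compound 1 `COc1ccc(-c2[nH]c3ccccc3c2/C=C(\C#N)S(=O)(=O)c2ccccc2)cc1` gives 1500 nM in a functional assay on SN12C cells (Homo sapiens) for inhibition, read by sulforhodamine B assay, with a stated time of 48 h (a higher number here means a weaker inhibitor of growth, a lower number a stronger inhibitor of growth), and compound 2 `N#C/C(=C\c1c(-c2ccccc2)[nH]c2ccccc12)S(=O)(=O)c1ccccc1` gives 5200 nM. The step of a 3.5-fold higher number from compound 1 to compound 2 (0.54 log units; beyond the scatter) is the only one measured, so compound 2 holds the highest number of the two. Compound 3 `N#C/C(=C\c1c(-c2ccccc2)[nH]c2ccccc12)C(=O)c1ccccc1` differs from compound 2 by benzoyl in place of phenylsulfonyl on a double-bonded chain carbon bound to a double-bonded chain carbon and a triple-bonded carbon. Within the data shown here, no measured step touches the sulfonyl-to-carbonyl exchange; the one step known concerns a methoxy group and says nothing about this change, so no shift beyond the scatter is expected. Compound 3 is therefore expected near compound 2, with the step of a 1.0-fold lower number from compound 2 to compound 3 (0.02 log units; within the scatter), at 5000 nM within 1500 nM to 16000 nM.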

Compound 3, concentration for 50% growth inhibition: 5700 nM
Beside the measured number, compound 3's estimate is 1.1-fold (0.06 log units) below it; low and high end bracket the measured number.
By their numbers in this assay, from the lowest: compound 1; then compounds 2 and 3 (each within the scatter of the next).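

In this assay the exchange of phenylsulfonyl for benzoyl on this double-bonded chain carbon gives a 1.1-fold higher number from compound 2 to compound 3 (0.04 log units; within the scatter) and so shows that, at this position, the sulfonyl group can give way to a carbonyl with no shift beyond the scatter. Among these compounds, the one earlier step concerned only methoxy and could not show this. Nothing given here explains the result. On these data alone, it remains open whether benzoyl behaves the same way alongside the methoxy of compound 1. As far as these compounds go, it also remains open how an amide or a carboxylic acid would behave at this carbon.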